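The source may report more compounds than this note shows. Statements on the series, on what has been measured and on what is new or still open speak of the compounds shown alone.

Values in an ADME assay (liver) for metabolic stability, with Liver microsome (Homo sapiens) as the target, using microsomes and NADPH, with a stated time of 30 min, tested at 1 uM (on this read-out lower numbers stand for slow clearance and higher numbers for fast clearance), so far:
Compound 1 `Nc1ccc(S(=O)(=O)N2CCN(c3ncc(C(O)(C(F)(F)F)C(F)(F)F)cc3C3CC3)CC2)cn1`: 38 mL.min-1.g-1
Compound 2 `Nc1ccc(S(=O)(=O)N2CCN(c3ncc(C(O)(C(F)(F)F)C(F)(F)F)cc3-c3ccncc3)CC2)cn1`: 15 mL.min-1.g-1
Compound 3 `Nc1ccc(S(=O)(=O)N2CCN(c3ncc(C(O)(C(F)(F)F)C(F)(F)F)cc3-c3ccc4c(c3)CC(=O)N4)CC2)cn1`: < 14 mL.min-1.g-1 (a limit, not a number)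

Compound 3 stands at the limit of < 14 mL.min-1.g-1 in this assay, at which 1 of the 3 values shown sits, and so is known only as a limit. Compound 4 `Nc1ccc(S(=O)(=O)N2CCN(c3ncc(C(O)(C(F)(F)F)C(F)(F)F)cc3-c3cc4ccccc4s3)CC2)cn1` carries 1-benzothiophen-2-yl instead: a group of 9 heavy atoms (8 carbon, 1 sulfur; one five-membered aromatic ring with 1 hetero atom, one six-membered aromatic ring of carbon only) in place of a group of 10 heavy atoms (8 carbon, 1 nitrogen, 1 oxygen; one five-membered non-aromatic ring with 1 hetero atom, one six-membered aromatic ring of carbon only), on an aromatic carbon. Among the measured compounds shown here, two steps bear on this change, a 2.5-fold lower number from compound 1 to compound 2 (0.40 log units; beyond the scatter) and an at least 2.7-fold lower number from compound 1 to compound 3 (0.43 log units; beyond the scatter), each putting a group with nitrogen in place of cyclopropyl. The step of an at least 1.0-fold lower number from compound 2 to compound 3 (0.02 log units; that floor lies within the scatter) adds little. The group entering compound 4 holds no nitrogen, so the lowering may not carry over, and a value nearer compound 1 at 38 mL.min-1.g-1 is expected. The expected change is an at least 2.2-fold higher number from compound 3 to compound 4 (0.35 log units; beyond the scatter) in this assay, upward and of modest size or more. Compound 4 is estimated at 32 mL.min-1.g-1, with an expected range of 15 mL.min-1.g-1 to 80 mL.min-1.g-1.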

Compound 4, intrinsic clearance in microsomes: < 14 mL.min-1.g-1
Compound 4: only a limit was reported; the forecaster's own chance of this, stated with the estimate: 20%; at least 2.2-fold (0.35 log units) between middle value and limit.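

In this assay, compound 4 is known only as a limit, not a number, yet 1-benzothiophen-2-yl at this position gives an at least 2.7-fold lower number from compound 1 to compound 4 (0.43 log units; beyond the scatter), so a lower number here does not require nitrogen in the entering group, which the groups of compound 2 and compound 3 both held. Against pyridin-4-yl the result is an at least 1.0-fold lower number from compound 2 to compound 4 (0.02 log units; that floor lies within the scatter), which sets no order. The remaining step cannot be read, because compound 3 and compound 4 share one floor: the limit of < 14 mL.min-1.g-1 in this assay, at which 2 of the 4 values shown sit.

As far as these compounds go, whether a plain phenyl group, with no fused ring and no hetero atom, also gives a lower number than cyclopropyl stays open. From the compounds shown here alone, the true values behind the limit also remain unknown.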